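The source may report more compounds than this note shows. Statements on the series, on what has been measured and on what is new or still open speak of the compounds shown alone.

Measured so far in an ADME assay on microsomes from liver (Homo sapiens) for metabolic stability, with a stated time of 30 min, tested at 1 uM; a higher number here means that the compound lasts longer, a lower number that the compound disappears faster:
Compound 1 `COc1ccc2[nH]c(C(=O)N3CC(=O)N(Cc4ccccc4)[C@@H](COc4ccccc4)C3)cc2c1` gives 0.65 h.
Compound 2 `COc1ccc2[nH]c(C(=O)N3CC(=O)N(Cc4ccccc4)[C@@H](N4CCc5ccccc54)C3)cc2c1` gives 0.25 h.
Compound 3 `COc1ccc2[nH]c(C(=O)N3CC(=O)N(Cc4ccccc4)[C@@H](CN4CCC(C(C)C)CC4)C3)cc2c1` gives 0.317 h.

Among these three numbers compound 3 stands second highest. Its gap to compound 2 is within the scatter, so the two cannot be ordered, while the step of a 2.1-fold lower number from compound 1 to compound 3 (0.31 log units; beyond the scatter) lies beyond the scatter, leaving compound 1 as the longest-lasting of the three.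

Compound 4 `COc1ccc2[nH]c(C(=O)N3CC(=O)N(Cc4ccccc4)[C@@H](CN4CCCc5ccccc54)C3)cc2c1` differs from compound 3 in one place: 1,2,3,4-tetrahydroquinolin-1-yl in place of 4-isopropylpiperidin-1-yl on a saturated chain carbon bound to a saturated ring carbon. For the measured compounds named here, two measured steps bear on this change. The step of a 2.1-fold lower number from compound 1 to compound 3 (0.31 log units; beyond the scatter) shows what happened when the 4-isopropylpiperidin-1-yl group took the place of phenoxy, and the step of a 2.6-fold lower number from compound 1 to compound 2 (0.41 log units; beyond the scatter) shows the effect of the 2,3-dihydro-1H-indol-1-yl group, a ring attached through its nitrogen and fused to an aromatic ring, much like the 1,2,3,4-tetrahydroquinolin-1-yl group that enters in compound 4. Both substitutions lowered the number, and the step of a 1.3-fold higher number from compound 2 to compound 3 (0.10 log units; within the scatter) between those two products was within the scatter. Compound 4 is therefore expected to stay close to compound 3, with no step beyond the scatter, a 1.1-fold lower number from compound 3 to compound 4 (0.05 log units; within the scatter).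

Compound 4 is estimated at 0.28 h, with a range from 0.14 h to 0.55 h in this assay.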

Compound 4, half-life: 0.183 h
The estimate for compound 4 lay 1.5-fold (0.18 log units) above the measured number; the measured number falls inside the stated range.
By their numbers in this assay, from the lowest: compounds 4, 2 and 3 (each within the scatter of the next); then compound 1.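

In this assay, the change on the saturated chain carbon bound to a saturated ring carbon gives a 1.7-fold lower number from compound 3 to compound 4 (0.24 log units; within the scatter) and so stays inside the scatter, which means that a nitrogen-attached ring with a six-membered aromatic ring of carbon only and the 4-isopropylpiperidin-1-yl group, which has no aromatic ring, cannot be told apart here. The same holds for the change from 2,3-dihydro-1H-indol-1-yl on the saturated ring carbon to (1,2,3,4-tetrahydroquinolin-1-yl)methyl, which gives a 1.4-fold lower number from compound 2 to compound 4 (0.14 log units; within the scatter) and leaves these two compounds unordered as well. Only the comparison with phenoxy stands out, with a 3.6-fold lower number from compound 1 to compound 4 (0.55 log units; beyond the scatter) as the largest step in the set, so compound 1 remains clearly apart from compound 2, compound 3 and compound 4, which form one group.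

The compounds shown leave open whether the higher number of compound 1 goes with the oxygen link or with the phenyl ring it carries, a question that a phenylamino group or a simple methoxy group on the same chain carbon could help to separate. Nothing at hand explains any of these differences in stability.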